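The source may report more compounds than this note shows. Statements on the series, on what has been measured and on what is new or still open speak of the compounds shown alone.

Of the compounds shown here, three sharing one core have been measured in an assay on HL-60 cells for agonist activity at vitamin D3 receptor (Homo sapiens), read by microscopy, with a stated time of 96 h; on this read-out higher numbers stand for an effect only at larger amounts of compound and lower numbers for an effect already at smaller amounts. Compound 1 `CC[C@@H](C)[C@H](NC(=O)c1ccc(C(CC)(CC)c2ccc(OCC(=O)C(C)(C)C)c(C)c2)n1CC)C(=O)OC` gives 590 nM. Compound 2 `CCn1c(C(=O)NCCCN(C)C)ccc1C(CC)(CC)c1ccc(OCC(=O)C(C)(C)C)c(C)c1` gives 96 nM. Compound 3 `CCn1c(C(=O)N(C)c2ccccc2)ccc1C(CC)(CC)c1ccc(OCC(=O)C(C)(C)C)c(C)c1` gives 18500 nM, the highest of the three numbers: a 31-fold higher number from compound 1 to compound 3 (1.50 log units; beyond the scatter) and a 190-fold higher number from compound 2 to compound 3 (2.28 log units; beyond the scatter). Compound 4 `CCn1c(C(=O)Nc2cccc(C(F)(F)F)c2)ccc1C(CC)(CC)c1ccc(OCC(=O)C(C)(C)C)c(C)c1` has not yet been measured; it differs from compound 3 by (3-(trifluoromethyl)phenyl)amino in place of methyl(phenyl)amino on a carbonyl carbon. Both measured steps arriving at compound 3 brought in methyl(phenyl)amino and raised the number by a large margin, so a group carrying 1 hydrogen-bond donor on the carbonyl carbon, as in compound 4, is expected to bring the number back down by a sizeable step. Compound 4 is therefore estimated at 1200 nM, a step of a 15-fold lower number from compound 3 to compound 4 (1.19 log units; beyond the scatter), with a range from 250 nM to 6000 nM.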

Compound 4, half-maximal effective concentration: > 50000 nM
Compound 4: a limit, no number (the forecaster's own chance of this, stated with the estimate: 5%); middle value at least 41-fold (1.61 log units) from the limit.
By their numbers in this assay, from the lowest: compound 2; then compound 1; then compound 3. At a limit, above all of these: compound 4.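

Compound 4 stands at a limit of the assay, not at a number: the limit of > 50000 nM in this assay, at which 1 of the 4 values shown sits. A hydrogen-bond donor on this amide nitrogen therefore did not bring the number down, with an at least 2.7-fold higher number from compound 3 to compound 4 (0.43 log units; beyond the scatter). Both aromatic amides sit high against the two open-chain amides, with an at least 84-fold higher number from compound 1 to compound 4 (1.92 log units; beyond the scatter) and an at least 520-fold higher number from compound 2 to compound 4 (2.71 log units; beyond the scatter). The compounds shown cannot separate the amide hydrogen from the trifluoromethyl group; plain phenylamino on the same carbonyl carbon would do so. They also leave open how a piperidine or a carboxylic acid on the amide-type nitrogen would read.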